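The source may report more compounds than this note shows. Statements on the series, on what has been measured and on what is new or still open speak of the compounds shown alone.

Of the compounds shown here, three on a shared core have been tested in an ADME assay on T29 cells (Homo sapiens) for cytotoxicity, read by sulforhodamine B assay, with a stated time of 3 days (on this read-out higher numbers stand for weaker inhibition and lower numbers for stronger inhibition), and none of them gave a number. Compound 2 (`OCc1cn(Cc2cccc(Br)c2)c2ccccc12`) carries a single bromo group and reads > 31600 nM as a limit of the assay. Compound 3 (`OCc1cn(Cc2ccc(Br)cc2)c2ccccc12`) also carries a single bromo group and reads > 31600 nM as a limit, not a number. Compound 3 therefore holds no rank of its own, since what the data show is the limit of > 31600 nM in this assay, at which 3 of the 3 values shown sit, and nothing finer.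

Compound 4 (`OCc1cn(Cc2ccc(Br)c(Br)c2)c2ccccc12`) comes from compound 3 by one change (bromo in place of hydrogen on an aromatic carbon): bromo in place of hydrogen on an aromatic carbon, ortho to a bromo group. Among the compounds with values here, no step between measured compounds is available to size this change, so the expectation rests on limits alone. Compound 1 (`O=Cc1cn(Cc2ccc(Br)c(Br)c2)c2ccccc12`) already carries two bromo groups and reads > 31600 nM as a limit too. On that reading, the step of a number no higher from compound 3 to compound 4 (the limit leaves the size open) is expected to stay within the usual scatter of this assay and to have no clear direction. The estimate for compound 4 is 31600 nM with an expected range from 12000 nM to 60000 nM and a report of the limit alone as the likeliest outcome.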

Compound 4, half-maximal inhibitory concentration: > 31600 nM
Compound 4: a limit, no number; the forecaster's own chance of this, stated with the estimate: 75%; the middle value lies on the limit itself.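

No step to compound 4 from compound 1, compound 2 or compound 3 can be read in this assay, because each of these compounds gives a limit and not a number: the limit of > 31600 nM in this assay, at which 4 of the 4 values shown sit.

The compounds shown leave open how strongly, if at all, any of them inhibits these cells, and how the bromo and hydroxymethyl changes compare in size.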